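The source may report more compounds than this note shows. Statements on the series, on what has been measured and on what is new or still open speak of the compounds shown alone.

Measured compounds:
- compound 1, `COc1ncnc2c1c(I)cn2[C@@H]1O[C@H](CO)[C@@H](O)[C@H]1O`: 1150 nM
- compound 2, `COc1ncnc2c1c(-c1ccccc1)cn2[C@@H]1O[C@H](CO)[C@@H](O)[C@H]1O`: a limit, > 20000 nM
- compound 3, `Cc1ncnc2c1c(-c1cc3ccccc3o1)cn2[C@@H]1O[C@H](CO)[C@@H](O)[C@H]1O`: 17300 nM

In a functional assay on CCRF-CEM cells (Homo sapiens), read by MTT assay, with a stated time of 72 h (a lower number here means a stronger inhibitor, a higher number a weaker inhibitor), compound 1 gives 1150 nM. Compound 2 gives no number in this assay, only its limit of > 20000 nM; this is the limit described as the limit of > 20000 nM in this assay, at which 1 of the 3 values shown sits. Compound 3 gives 17300 nM, the higher of the two numbers measured, with compound 1 the lower. Among the compounds with values here, the one measured step, an at least 17-fold higher number from compound 1 to compound 2 (1.24 log units; beyond the scatter), concerns a change at a different position of the shared core and does not touch the change now in question.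

Compound 4, `COc1ncnc2c1c(-c1cc3ccccc3o1)cn2[C@@H]1O[C@H](CO)[C@@H](O)[C@H]1O`, differs from compound 3 by methoxy in place of methyl on an aromatic carbon. Within the data shown here, no measured pair isolates this change, so the expectation rests on the weak numbers of compound 3 and on the limit of compound 2, which carries the same methoxy group. Compound 4 is therefore expected to stay in the weak range, with a fair chance of reaching the limit. The expected step of a 1.2-fold higher number from compound 3 to compound 4 (0.06 log units; within the scatter) is estimated to be small. Compound 4 is estimated at 20000 nM, between 8000 nM and 50000 nM.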

Compound 4, half-maximal inhibitory concentration: 5370 nM
For compound 4 the middle estimate is 3.7-fold (0.57 log units) above the measured one, and the stated range ends above it.
By their numbers in this assay, from the lowest: compound 1; then compound 4; then compound 3. At a limit, above all of these: compound 2.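

In this assay, within the data shown here, the pair of compound 3 and compound 4 isolates this change for the first time: methoxy in place of methyl on the six-membered aromatic ring gives a 3.2-fold lower number from compound 3 to compound 4 (0.51 log units; beyond the scatter), so this small swap matters while 1-benzofuran-2-yl stays fixed. With methoxy held constant, 1-benzofuran-2-yl in place of phenyl gives an at least 3.7-fold lower number from compound 2 to compound 4 (0.57 log units; beyond the scatter), a bound and not an exact size, since compound 2 rests on a limit: the limit of > 20000 nM in this assay, at which 1 of the 4 values shown sits. Iodo still outperforms 1-benzofuran-2-yl, with a 4.7-fold higher number from compound 1 to compound 4 (0.67 log units; beyond the scatter).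

On these data alone, it remains open whether methoxy would also beat methyl with iodo or phenyl on the other ring carbon. Also open, as far as these compounds go, is what an amine or a longer chain, such as ethoxy, would do in place of methoxy.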